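A few compounds are considered here, and "the series" means these few. Any claim that something is new, unique, unknown or untested is made for them only; others in the source may bear on it.

In a physicochemical assay for lipophilicity, at pH 7.4 (on this read-out higher numbers stand for higher lipophilicity and lower numbers for lower lipophilicity), compound 1 `CCc1ccc(N(C2COC2)S(=O)(=O)c2ccc3c(c2)C(O)CC(C2CCOCC2)O3)cc1` gives 2.63, the lowest of three readings. Compound 3 `CCc1ccc(N(CC(C)C)S(=O)(=O)c2ccc(OCC3CCOCC3)c3c2CCC3O)cc1` gives 4.55 and compound 2 `CCc1ccc(N(CC(C)C)S(=O)(=O)c2ccc3c(c2)C(C)CC(C2CCOCC2)O3)cc1` gives 5.71, both beyond the scatter from compound 1. Compound 4 `CCc1ccc(N(CC2CCC2)S(=O)(=O)c2ccc3c(c2)C(O)CC(C2CCOCC2)O3)cc1` has not yet been measured. It keeps the core of compound 1 but carries cyclobutylmethyl in place of oxetan-3-yl on a sulfonamide nitrogen. For the measured compounds named here, no measured pair shows this swap alone, so the expectation rests on the swap itself, where a ring of carbon only replaces one with a hetero atom, and on the reading of compound 3 at 4.55. A clear rise beyond the scatter is expected in this assay, estimated as a number 1.87 log units higher from compound 1 to compound 4 (beyond the scatter). For compound 4 the estimated value is 4.5, within a range of 3.9 to 5.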

Compound 4, distribution coefficient: 4.01
Beside the measured number, compound 4's estimate is 0.49 log units above it; measured number inside the range.
By their numbers in this assay, from the lowest: compound 1; then compound 4; then compound 3; then compound 2.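

On a sulfonamide nitrogen of the shared core, cyclobutylmethyl in place of oxetan-3-yl gives a number 1.38 log units higher from compound 1 to compound 4 (beyond the scatter) in this assay. For the compounds shown here, this is the first change at this position that can be read alone, since the earlier compounds differed from one another in more than one place. Nothing measured here accounts for the size of this step.

From the compounds shown here alone, the swap removes the ring oxygen and adds a methylene link together, so their separate shares stay open. Oxetan-3-ylmethyl or plain cyclobutyl on this nitrogen would separate them, and how an amine would read there also remains open.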